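From 4-nitrobenzyl to (furan-2-yl)methyl on a shared core

The source may hold more compounds than are shown below. What is called first, only, known or untested is meant among the compounds shown, and "the series" means these compounds.

- compound 1 `Cc1cc(=O)c2c(O)cc(OCc3ccc(Br)cc3)c([C@H]3CCN(C)C[C@H]3O)c2o1` gives 14%
- compound 2 `Cc1cc(=O)c2c(O)cc(OCc3ccc([N+](=O)[O-])cc3)c([C@H]3CCN(C)C[C@H]3O)c2o1` gives 39%

Of the two measured compounds, compound 2 stands highest in a functional assay on MCF7 cells (Homo sapiens) for inhibition, read by MTT assay, with a stated time of 48 h, tested at 10 uM (a lower number here means less inhibition of growth, a higher number more inhibition of growth at the concentration tested), with 39% and is the starting point here. The next compound is compound 3 `Cc1cc(=O)c2c(O)cc(OCc3ccco3)c([C@H]3CCN(C)C[C@H]3O)c2o1`, which has not yet been measured. The change is furan-2-yl in place of 4-nitrophenyl on a saturated chain carbon bound to an oxygen on an aromatic ring. For the measured compounds named here, only one measured step bears on this change, and it is a number 25 percentage points higher from compound 1 to compound 2 (beyond the scatter), with nitro in place of bromo on an aromatic carbon. That modest step went upward with the nitro group, which now leaves along with the whole six-membered ring. Going by the values given here, no measured step replaces that ring outright, so the evidence is thin and the range must stay wide. The expected change is a number 17 percentage points lower from compound 2 to compound 3 (beyond the scatter) in this assay and this modest downward move is only an estimate. For compound 3 the estimated value is 22% (expected range 6% to 42%).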

Compound 3, percent growth inhibition at one concentration: 6%
Beside the measured number, compound 3's estimate is 16 percentage points above it, and the stated range covers the measured number.
By their numbers in this assay, from the lowest: compounds 3 and 1 (each within the scatter of the next); then compound 2.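

On the saturated chain carbon bound to an oxygen on an aromatic ring, replacing the whole aromatic group matters in this assay: furan-2-yl in place of 4-nitrophenyl gives a number 33 percentage points lower from compound 2 to compound 3 (beyond the scatter). The same replacement of 4-bromophenyl gives a number 8 percentage points lower from compound 1 to compound 3 (within the scatter), so furan-2-yl and 4-bromophenyl cannot be told apart in this read-out. For the compounds shown here, the earlier pair showed only that the group on the six-membered ring could shift the result, whereas the three compounds now show that, of the groups tested at this position, only 4-nitrophenyl stands clear of the other two. Nothing measured here accounts for that difference.

The compounds shown leave open whether the higher number of compound 2 depends on the nitro group itself, since no other group on that aromatic carbon besides bromo appears here, and an amine or a carboxylic acid there would test this. They also leave open whether a five-membered ring can reach that level when it carries a nitro group, or whether an unsubstituted phenyl group would fall with compound 1 and compound 3.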